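A few compounds are considered here, and "the series" means these few. Any claim that something is new, unique, unknown or untested is made for them only; others in the source may bear on it.

Of the compounds shown here, three have been measured in an assay on COS-7 cells for inhibition of patatin-like phospholipase domain-containing protein 2 (Mus musculus), tested at 200 uM; on this read-out lower numbers stand for less inhibition and higher numbers for more inhibition at the one concentration tested (going by the name of the read-out). Compound 1, `CCOC(=O)c1cccc(-c2ccc(CN3CCCC3)cc2)c1`, gives 33% in this assay. Compound 2, `CCOC(=O)c1cccc(-c2ccc3c(ccn3C)c2)c1`, gives 84% in this assay. Compound 3, `CCOc1ccc(-c2cccc(C)c2)cc1`, gives 54% in this assay. Compound 3 therefore stands second highest of the three numbers: its number lies above that of compound 1 and below that of compound 2, and both gaps are beyond the usual scatter of this kind of measurement. No two of these three compounds differ in a single place, so none of these gaps can be tied to one structural change.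

Compound 4, `CCOc1ccc(-c2cccc(NC(=O)N(C)C)c2)cc1`, has not yet been measured. It differs from compound 3 in one place: (dimethylcarbamoyl)amino in place of methyl on an aromatic carbon. Among the compounds with values here, the data contain no other pair in which a (dimethylcarbamoyl)amino group replaces a methyl group, so nothing measured shows how this change moves the number in this assay.

In the absence of such a comparison, the step expected from compound 3 to compound 4 is a number 4 percentage points lower from compound 3 to compound 4 (within the scatter), a step estimated to stay within the usual scatter. Compound 4 is accordingly estimated to give 50% in this assay, with a range from 25% to 75%.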

Compound 4, a percentage reported as inhibition, at one concentration (the size of the read-out at that concentration, not a potency): 68%
Compound 4: middle estimate off by 18 percentage points, on the low side; low and high end bracket the measured number.
By their numbers in this assay, from the lowest: compound 1; then compound 3; then compound 4; then compound 2.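

In this assay, within the data shown here, the one comparison that isolates a single structural change gives a number 14 percentage points higher from compound 3 to compound 4 (beyond the scatter), with (dimethylcarbamoyl)amino in place of methyl on an aromatic carbon. This shows that the number responds to what stands at this position, and that the methyl group is not needed there for the inhibition seen at the one concentration tested, since a larger group carrying a hydrogen-bond donor and a hydrogen-bond acceptor is accepted with a higher number. Nothing available explains why this change raises the number.

This single pair leaves open which part of the entering group accounts for the step: the amide hydrogen, the carbonyl or the methyl groups of the dimethylcarbamoyl part, which a primary amine, an acetamide or a dimethylamino group at the same place could help to separate. It also leaves open whether the same change would move the number in the same direction on another core, such as the core of compound 2.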